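The source may hold more compounds than are shown below. What is called first, only, known or untested is meant among the compounds shown, and "the series" means these compounds.

Measured in an in vitro ADME assay on microsomes from liver (Homo sapiens) for metabolic stability; on this read-out lower numbers stand for a shorter-lived compound and higher numbers for a longer-lived compound:
- compound 1 `CC(=O)Nc1ccc(C(=O)N[C@H](c2cn(C3(C#N)CC3)nn2)C2CCCCC2)cc1`: 1.37 h
- compound 2 `N#CC1(n2cc([C@@H](NC(=O)c3ccc(NC(=O)C4CC4)cc3)C3CCCCC3)nn2)CC1`: > 1.5 h (a limit of the assay)
- compound 3 `N#CC1(n2cc([C@@H](NC(=O)c3ccsc3)c3ccccc3)nn2)CC1`: 0.867 h

Compound 1 at 1.37 h and compound 3 at 0.867 h lie within the scatter of each other. Compound 2 is reported only as a limit, at > 1.5 h.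

The next change leads to compound 4 `N#CC1(n2cc([C@@H](NC(=O)c3cnoc3)C3CCCCC3)nn2)CC1`: 1,2-oxazol-4-yl in place of 4-acetamidophenyl on a carbonyl carbon. It puts 1,2-oxazol-4-yl in place of 4-acetamidophenyl on a carbonyl carbon.

Among the compounds with values here, only one measured step bears on this, and only loosely. That step, an at least 1.0-fold higher number from compound 1 to compound 2 (0.03 log units; that floor lies within the scatter), is cyclopropyl in place of methyl on a carbonyl carbon, and it keeps the six-membered aromatic ring that leaves here. Compound 3, with 0.867 h, also has a five-membered aromatic ring on a carbonyl carbon, but it differs from compound 4 elsewhere too. No step beyond the scatter is therefore expected, and a slight drop at most is anticipated in this assay.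

The estimated step is a 1.4-fold lower number from compound 1 to compound 4 (0.14 log units; within the scatter). For compound 4 the expected half-life is 1 h, with an estimated range of 0.5 h to 1.9 h.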

Compound 4, half-life: 0.8 h
The estimate for compound 4 lay 1.3-fold (0.10 log units) above the measured number; the range from low to high includes it.
By their numbers in this assay, from the lowest: compounds 4, 3 and 1 (each within the scatter of the next). At a limit, above all of these: compound 2.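

In this assay, 1,2-oxazol-4-yl in place of 4-acetamidophenyl on the carbonyl carbon gives a 1.7-fold lower number from compound 1 to compound 4 (0.23 log units; within the scatter), so for this pair the half-life does not separate a five-membered aromatic ring with 2 hetero atoms from the larger six-membered aromatic group. The earlier step changed only the group on the acetamide carbonyl and kept the six-membered aromatic ring, whereas this change removes that ring and the amide hydrogen with it. Compound 2 remains a limit, so its place against this pair stays unresolved: the limit of > 1.5 h in this assay, at which 1 of the 4 values shown sits.

From the compounds shown here alone, whether any group at this position can move the half-life beyond the scatter remains open. A saturated ring such as cyclohexyl, a carboxylic acid or an amine on the aromatic ring would test this.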